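The source may report more compounds than this note shows. Statements on the series, on what has been measured and on what is new or still open speak of the compounds shown alone.

Of the compounds shown here, three sharing a core have been tested in a functional assay on HT-1080 cells (Homo sapiens) for antiproliferative activity, read by MTT assay, with a stated time of 72 h (a higher number here means a weaker inhibitor, a lower number a stronger inhibitor), so far. Compound 1 `CCOC(=O)c1cc(-c2cc(OC)c(OC)c(OC)c2)c(-c2ccc(OC)c(O)c2)s1` gives 3220 nM and compound 2 `COc1ccc(-c2sccc2-c2cc(OC)c(OC)c(OC)c2)cc1` gives 4590 nM, two values within the usual scatter of each other. Compound 3 `COc1ccc(-c2sccc2-c2cc(OC)c(OC)c(OC)c2)cc1OCc1ccccc1` gives > 100000 nM, which is a limit of the assay and not a number. Among the measured compounds shown here, the only measured step, an at least 21-fold higher number from compound 2 to compound 3 (1.33 log units; beyond the scatter), comes with benzyloxy in place of hydrogen on an aromatic carbon.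

Compound 4 `COc1ccc(-c2sccc2-c2cc(OC)c(OC)c(OC)c2)cc1O` takes the benzyl away again: hydrogen in place of benzyl on an oxygen on an aromatic ring. In short, benzyloxy becomes hydroxy, with hydrogen in place of benzyl on an oxygen on an aromatic ring. The large measured step bears most directly on this change, though it is not the exact reverse, since compound 4 keeps an oxygen that compound 2 lacks. Compound 1 also carries a hydroxy group, differs elsewhere too, and gives 3220 nM in this assay. Losing the benzyl should therefore bring the number down into the region of the two measured values. A large step towards a stronger inhibitor is expected, estimated as an at least 66-fold lower number from compound 3 to compound 4 (1.82 log units; beyond the scatter) here. Compound 4 is expected at about 1500 nM, with an estimated range from 100 nM to 9000 nM as its likely span.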

Compound 4, half-maximal inhibitory concentration: 1940 nM
Estimate against measurement, compound 4: 1.3-fold (0.11 log units) below, within the range that was stated.
By their numbers in this assay, from the lowest: compounds 4, 1 and 2 (each within the scatter of the next, the first and the last beyond it). At a limit, above all of these: compound 3.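

In this assay the step of an at least 51-fold lower number from compound 3 to compound 4 (1.71 log units; beyond the scatter) rests on a limit for compound 3 and not on a number, yet it ties the loss to the benzyl and not to the oxygen that carries it. The oxygen can stay as long as it bears hydrogen, and the step of a 2.4-fold lower number from compound 2 to compound 4 (0.37 log units; beyond the scatter) shows that hydroxy in place of hydrogen on this aromatic carbon gives a modest gain, which compound 3 alone could not suggest. The step of a 1.7-fold lower number from compound 1 to compound 4 (0.22 log units; within the scatter) adds a second place on the shared core: hydrogen and ethoxycarbonyl on that aromatic carbon cannot be told apart in this assay, so at least in the presence of the hydroxy, this place accepts either group.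

As far as these compounds go, what lies between hydrogen and benzyl on the oxygen remains open, and a methyl or an ethyl there would show whether a small group is accepted or whether any group brings the number up. From the compounds shown here alone, whether the oxygen itself is needed also remains open, a question that an amine in place of the hydroxy would address.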